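The compounds below may be only part of what the source reports. "The series", "measured", "known", "first", "only" and "open" are said of these compounds alone.

Three amides on one shared core have been run so far. Compound 1 `O=C(Nc1cccc([N+](=O)[O-])c1)C1CCCN(C(=O)c2cc(C(F)(F)F)cc(C(F)(F)F)c2)C1` carries a nitro on an aromatic carbon of its aniline part; in an ADME assay on PC-3 cells (Homo sapiens) for cytotoxicity, read by WST assay, tested at 100 uM (on this read-out higher numbers stand for more inhibition at the one concentration tested (going by the name of the read-out) and lower numbers for less inhibition), compound 1 gives 9%. Compound 2 `O=C(Nc1cccc(Oc2ccccc2)c1)C1CCCN(C(=O)c2cc(C(F)(F)F)cc(C(F)(F)F)c2)C1` has phenoxy in that place, and in this assay compound 2 gives 1%. Compound 3 `COC(=O)c1cc(-c2cccc(NC(=O)C3CCCN(C(=O)c4cc(C(F)(F)F)cc(C(F)(F)F)c4)C3)c2)co1` carries 5-(methoxycarbonyl)furan-3-yl there, and in this assay compound 3 gives 0%.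

Where compound 3 stands: the step was a number 9 percentage points lower from compound 1 to compound 3 (within the scatter), and a number 1 percentage points lower from compound 2 to compound 3 (within the scatter); compound 3 thus sits within the scatter of both other numbers, and none of the three readings can be set apart from another.

Compound 4 `CC(C)(C)OC(=O)c1cccc(NC(=O)C2CCCN(C(=O)c3cc(C(F)(F)F)cc(C(F)(F)F)c3)C2)c1` is the next member. tert-butoxycarbonyl in place of 5-(methoxycarbonyl)furan-3-yl on an aromatic carbon

Going by the values given here, the steps that bear on this change are those that already swapped the group on this same aromatic carbon: nitro to phenoxy, a number 8 percentage points lower from compound 1 to compound 2 (within the scatter); nitro to the furanyl, a number 9 percentage points lower from compound 1 to compound 3 (within the scatter); phenoxy to the furanyl, a number 1 percentage points lower from compound 2 to compound 3 (within the scatter). Every such swap has stayed within the scatter, so no step beyond the scatter is expected in this assay for the swap to tert-butoxycarbonyl either: a number 4 percentage points higher from compound 3 to compound 4 (within the scatter) is the expected step, with no direction claimed. For compound 4 the estimate in this assay is 4%, within 0% to 15%.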

Compound 4, a percentage reported as inhibition, at one concentration (the size of the read-out at that concentration, not a potency): 0%
For compound 4 the middle estimate is 4 percentage points above the measured one; the range from low to high includes it.
By their numbers in this assay, from the lowest: compounds 3, 4, 2 and 1 (each within the scatter of the next).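

Working from this assay, the swap to tert-butoxycarbonyl gives no change at the digits printed from compound 3 to compound 4 (within the scatter), so this group with no ring, on an aromatic carbon meta to a large group, cannot be told apart from the five-membered aromatic ring group it replaces. Going by these compounds alone, the comparisons with the other two groups read the same way (a number 1 percentage points lower from compound 2 to compound 4 (within the scatter)) and (a number 9 percentage points lower from compound 1 to compound 4 (within the scatter)), which means four groups at this position, two carrying a ring and two without one, now give readings that cannot be set apart, and no step here has left the scatter. No measurement at hand speaks to why these readings fall together.

Still open, as far as these compounds go, is whether any group on this aromatic carbon can move the reading beyond the scatter, and a free carboxylic acid, a primary amine or a longer alkyl chain would put that to the test. Also open, from the compounds shown here alone, is whether a change elsewhere on the shared core, such as trifluoromethyl replaced by chlorine or by a nitrile on the benzoyl part, would do so.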